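Phenethyl in place of tert-butyl: an expected step

The source may report more compounds than this note shows. Statements on the series, on what has been measured and on what is new or still open speak of the compounds shown alone.

Compound 3 `CC(C)(C)c1cn(Cc2cc(=O)oc3cc(O)ccc23)nn1` gives 67600 nM in a functional assay on A549 cells (Homo sapiens) for inhibition, read by MTT assay, with a stated time of 72 h (on this read-out lower numbers stand for stronger inhibition and higher numbers for weaker inhibition), the second highest of three numbers. Compound 1 `O=c1cc(Cn2cc(CCCCl)nn2)c2ccc(O)cc2o1` gives 30100 nM, and compound 2 `O=c1cc(Cn2cc(CCCO)nn2)c2ccc(O)cc2o1` gives 96200 nM. Going by the values given here, two measured steps concern the same aromatic carbon: a 2.2-fold higher number from compound 1 to compound 3 (0.35 log units; beyond the scatter) and a 1.4-fold lower number from compound 2 to compound 3 (0.15 log units; within the scatter). Compound 4 `O=c1cc(Cn2cc(CCc3ccccc3)nn2)c2ccc(O)cc2o1` carries phenethyl in place of tert-butyl on an aromatic carbon. Among the compounds with values here, no measured step exchanges tert-butyl for a group holding a ring, so the known steps set only the scale: exchanges at this carbon have moved the number modestly at most. The expected step is therefore small, a 1.7-fold lower number from compound 3 to compound 4 (0.23 log units; within the scatter). The estimate for compound 4 is 40000 nM, expected to fall between 15000 nM and 110000 nM.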

Compound 4, half-maximal inhibitory concentration: 24800 nM
The estimate for compound 4 lay 1.6-fold (0.21 log units) above the measured number; low and high end bracket the measured number.
By their numbers in this assay, from the lowest: compounds 4 and 1 (each within the scatter of the next); then compounds 3 and 2 (each within the scatter of the next).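

The first group holding a ring at this aromatic carbon gives stronger inhibition in this assay than tert-butyl (a 2.7-fold lower number from compound 3 to compound 4 (0.44 log units; beyond the scatter)) and than the hydroxyl-ended chain, where phenyl replaces hydroxymethyl (a 3.9-fold lower number from compound 2 to compound 4 (0.59 log units; beyond the scatter)). Yet phenyl in place of chloromethyl stays within the scatter (a 1.2-fold lower number from compound 1 to compound 4 (0.08 log units; within the scatter)), so the ring brings no gain over the chlorine-ended chain. Nothing available here accounts for these steps.

Going by these compounds, whether the number responds to substitution on the phenyl ring remains open, for instance an amine or a carboxylic acid there. A longer chain carrying the phenyl also remains untested in the compounds shown.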